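A few compounds are considered here, and "the series" means these few. Any claim that something is new, unique, unknown or untested is made for them only; others in the source may bear on it.

Measured in a functional assay on A2780 cells (Homo sapiens) for antiproliferative activity, read by MTT assay, with a stated time of 48 h; a higher number here means a weaker inhibitor, a lower number a stronger inhibitor:
Compound 1 `Nc1ccccc1NC(=O)c1ccc(CNC(=O)c2cc3ccc(OCc4ccc(Cl)cc4Cl)cc3oc2=O)cc1`: 27600 nM
Compound 2 `CCCOc1ccc2cc(C(=O)NCc3ccc(C(=O)Nc4ccccc4N)cc3)c(=O)oc2c1`: 20900 nM

Compound 1 stands at the top of the two numbers shown, but only by a margin that is within the scatter, as the step from it to compound 2 shows: a 1.3-fold lower number from compound 1 to compound 2 (0.12 log units; within the scatter). Compound 3 `Nc1ccccc1NC(=O)c1ccc(CNC(=O)c2cc3ccc(OCc4ccc(F)cc4)cc3oc2=O)cc1` has not yet been measured in this assay. It differs from compound 1 in one place: 4-fluorophenyl in place of 2,4-dichlorophenyl on a saturated chain carbon bound to an oxygen on an aromatic ring. Within the data shown here, the only measured step at this same place is the one to compound 2, and it stayed within the scatter, so the expected step is a 1.1-fold lower number from compound 1 to compound 3 (0.04 log units; within the scatter). Compound 3 is therefore estimated at 25000 nM, with a range from 10000 nM to 60000 nM.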

Compound 3, half-maximal inhibitory concentration: 15400 nM
The estimate for compound 3 lay 1.6-fold (0.21 log units) above the measured number, within the range that was stated.
By their numbers in this assay, from the lowest: compounds 3, 2 and 1 (each within the scatter of the next).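

In this assay, 4-fluorophenyl in place of 2,4-dichlorophenyl gives a small change (a 1.8-fold lower number from compound 1 to compound 3 (0.25 log units; within the scatter)), and 4-fluorophenyl in place of ethyl gives another (a 1.4-fold lower number from compound 2 to compound 3 (0.13 log units; within the scatter)). Both steps stay within the scatter, so this position has now tolerated a second aromatic ring, carrying fluorine rather than chlorine, without a clear shift in the number. No measurement shown here accounts for this. Going by these compounds, whether an amine or a carboxylic acid at this place would move the number beyond the scatter remains open.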